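The source may report more compounds than this note shows. Statements on the series, on what has been measured and on what is new or still open speak of the compounds shown alone.

Measured so far:
- Compound 1 `CN(C(=O)CNC(=O)CN1CCCCC1)c1ccc(Cl)cc1C(=O)c1ccccc1Cl`: > 100 mg/kg
- Compound 2 `CN(C(=O)CNC(=O)CN)c1ccc([N+](=O)[O-])cc1C(=O)c1ccccc1Cl`: 10 mg/kg
- Compound 3 `NCC(=O)NCC(=O)Nc1ccc([N+](=O)[O-])cc1C(=O)c1ccccc1`: 24.8 mg/kg

The compounds were tested in a functional assay on the whole organism with Mus musculus as the target, in the rotarod test; on this read-out higher numbers stand for an effect only at larger amounts of compound and lower numbers for an effect already at smaller amounts. Compound 3 has the higher of the two exact numbers, and compound 2 lies lower at 10 mg/kg, a gap beyond the usual scatter. For compound 1, > 100 mg/kg is a limit and not a number.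

Compound 4 `NCC(=O)NCC(=O)Nc1ccc([N+](=O)[O-])cc1C(=O)c1ccccc1Cl` has chloro in place of hydrogen on an aromatic carbon of compound 3, ortho to a large group: chloro in place of hydrogen on an aromatic carbon. For the measured compounds named here, no measured pair shows this change alone. Compound 2 carries the same 2-chlorophenyl and gives 10 mg/kg, so a modest move to a lower number is expected. Compound 1 also carries that group and gave only a limit. The expected change is a 2.1-fold lower number from compound 3 to compound 4 (0.32 log units; beyond the scatter). The estimate for compound 4 is 12 mg/kg, with an expected range of 4 mg/kg to 35 mg/kg.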

Compound 4, dose for half-maximal effect: 63.9 mg/kg
For compound 4 the middle estimate is 5.3-fold (0.73 log units) below the measured one; the whole stated range lies below it.
By their numbers in this assay, from the lowest: compound 2; then compound 3; then compound 4. At a limit, above all of these: compound 1.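

In this assay, chloro in place of hydrogen on this aromatic carbon, ortho to a large group, gives a 2.6-fold higher number from compound 3 to compound 4 (0.41 log units; beyond the scatter), so the change raises the number rather than lowering it. Hydrogen in place of methyl on the amide-type nitrogen, with the 2-chlorophenyl kept, gives a 6.4-fold higher number from compound 2 to compound 4 (0.81 log units; beyond the scatter), so the low number seen earlier with this group cannot be credited to the chloro alone. Nothing given here explains either step. Going by these compounds, whether fluoro or methoxy at this position would act like chloro remains open. So does whether the chloro step would run the same way with methyl on that nitrogen.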